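One Swap on the Amide Nitrogen, One Expected Number

The compounds below may be only part of what the source reports. "The series", "measured", "known", "first", "only" and "open" are said of these compounds alone.

Three compounds share one core. Compound 1 `CC[C@H](C)[C@H](NC(=O)c1cccc(Cn2ccnc2)c1)C(=O)NS(=O)(=O)c1ccccc1` was tested in an assay on HEK293 cells for displacement of a labelled ligand from Type-2 angiotensin II receptor (Homo sapiens), tested at 1 uM (a higher number here means a stronger effect of the compound at the concentration tested, a lower number a weaker effect), and gives 5%. Compound 2 `CCCCS(=O)(=O)NNC(=O)[C@@H](NC(=O)c1cccc(Cn2ccnc2)c1)[C@@H](C)CC` carries a (butylsulfonyl)amino group on an amide-type nitrogen, but in this assay compound 2 gives "not determined" (no result reported), so it stands nowhere on the numbers shown. Compound 3 `CC[C@H](C)[C@H](NC(=O)c1cccc(Cn2ccnc2)c1)C(=O)Nc1nccs1` differs from compound 2 in one place: 1,3-thiazol-2-yl in place of (butylsulfonyl)amino on an amide-type nitrogen The (butylsulfonyl)amino group leaves and 1,3-thiazol-2-yl enters. With no number for compound 2 and only compound 1 as a guide, no step beyond the usual scatter is expected in this assay. Compound 3 is expected to give about 7%, within a range from 0% to 25%.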

Compound 3, a percentage reported as inhibition, at one concentration (the size of the read-out at that concentration, not a potency): 4%
Compound 3: middle estimate off by 3 percentage points, on the high side, and the stated range covers the measured number.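

In this assay, putting 1,3-thiazol-2-yl in place of phenylsulfonyl on an amide-type nitrogen gives a number 1 percentage points lower from compound 1 to compound 3 (within the scatter) and so shows that two quite different groups at this position can give results the assay cannot tell apart. The step from compound 2 to compound 3 cannot be read, as compound 2 has no number. No measurement shown here offers an explanation for this result.

From the compounds shown here alone, whether an amine or a carboxylic acid on this amide-type nitrogen would give a clearly stronger effect stays open. So does whether any change to the shared core would lift the read-out beyond the scatter.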